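A few compounds are considered here, and "the series" means these few. Any claim that something is new, unique, unknown or untested is made for them only; others in the source may bear on it.

Among the measured compounds shown here, in an ADME assay on MT4 cells (Homo sapiens) for cytotoxicity (a lower number here means that less compound is tolerated, a higher number that more compound is tolerated), compound 1 `FC(F)(F)c1cccc(NC(=S)Nc2ccc(Cl)cc2)c1` gives 6800 nM and stands lowest of the two numbers so far. Compound 2 `CCCCc1ccc(NC(=S)Nc2cccc(C(F)(F)F)c2)c(C)c1` gives 43000 nM and so lies higher, by a gap beyond the usual scatter. For the measured compounds named here, these two compounds differ in more than one place, so the measurements offer no single-change step to lean on. Compound 3 `Fc1ccc(NC(=S)Nc2cccc(C(F)(F)F)c2)cc1` is still unmeasured and keeps the core of compound 1 while one group changes: fluoro in place of chloro on an aromatic carbon is the whole difference, with fluoro in place of chloro on an aromatic carbon, or 4-chlorophenyl to 4-fluorophenyl. Only this one substituent is exchanged. A modest step in this assay is expected, towards a higher number and possibly not far beyond the scatter. The expectation takes compound 1 at 6800 nM as its starting point. The estimated step of a 1.8-fold higher number from compound 1 to compound 3 (0.25 log units; within the scatter) is a small rise. For compound 3 the expected value is 12000 nM within an estimated range from 5000 nM to 35000 nM in this assay.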

Compound 3, half-maximal cytotoxic concentration: 31000 nM
Compound 3: the middle estimate sits 2.6-fold (0.41 log units) below what was measured; the range from low to high includes it.
By their numbers in this assay, from the lowest: compound 1; then compounds 3 and 2 (each within the scatter of the next).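

In this assay, the exchange of chloro for fluoro provides the only single-change comparison among the compounds shown, a modest step (a 4.6-fold higher number from compound 1 to compound 3 (0.66 log units; beyond the scatter)) that lies beyond the scatter. The two earlier compounds differ in more than one place, so they could not isolate any one position; this pair shows that the aromatic carbon para to a large group is sensitive to which of these two halogens it carries. One heavy atom is replaced, no ring or net charge is involved, and the count of hydrogen-bond donors and acceptors stays the same, yet the number still moves clearly upward, although nothing available here accounts for this step.

A single pair cannot show whether the higher number is particular to fluoro or would also appear with a hydrogen, a methyl, a methoxy or a trifluoromethyl at the same place. Going by these compounds, it also remains open whether the same exchange would give a similar step in a compound carrying the butyl chain of compound 2.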